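The source may hold more compounds than are shown below. What is called first, only, known or untested is meant among the compounds shown, and "the series" means these compounds.

Compound 1, `CC(=O)SC(SC(C)=O)c1cn(CCCCCOc2ccc(C#N)cc2)c2ccccc12`, gives in an ADME assay on J774.A1 cells (Mus musculus) for cytotoxicity, read by MTT assay, with a stated time of 72 h (a higher number here means that more compound is tolerated, a lower number that less compound is tolerated), a value that is a limit of the assay: > 100 ug/mL. Compound 2, `CC(=O)SC(SC(C)=O)c1cn(CCCCCCOc2ccc(C#N)cc2)c2ccccc12`, gives a limit as well: > 100 ug/mL.

Compound 2 therefore stands at the limit, as do both shown values (the limit of > 100 ug/mL in this assay, at which 2 of the 2 values shown sit). Compound 3, `CC(=O)SC(SC(C)=O)c1cn(CCCCOc2ccc(C#N)cc2)c2ccccc12`, carries the change (4-cyanophenoxy in place of 2-(4-cyanophenoxy)ethyl on a saturated chain carbon, four bonds along the chain from an aromatic nitrogen). Going by the values given here, the only measured step, a step that the two limits leave unreadable from compound 1 to compound 2, shortens the same chain and is unreadable, so no size can be taken from it. Compound 3 is therefore expected to show a step that the limit leaves unreadable from compound 2 to compound 3, nothing beyond the scatter, and is estimated at 120 ug/mL with a range from 60 ug/mL to 250 ug/mL.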

Compound 3, half-maximal cytotoxic concentration: > 100 ug/mL
Compound 3 ended at the assay's limit (the forecaster's own chance of this, stated with the estimate: 80%); the middle value is on the limit's open side.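

No step among compound 1, compound 2 and compound 3 can be read, since each value is a limit: the limit of > 100 ug/mL in this assay, at which 3 of the 3 values shown sit.

Going by these compounds, whether these three compounds differ at all in this assay remains open.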